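Methoxyphenyl to Nitrophenyl on the Ring Nitrogen

The source may report more compounds than this note shows. Statements on the series, on what has been measured and on what is new or still open speak of the compounds shown alone.

Of the compounds shown here, two sharing a core have been measured in a functional assay on the whole organism for inhibition, with Mus musculus as the target, at a dose of 25 mg/kg by the oral route; a higher number here means more inhibition at the dose given (going by the name of the read-out), a lower number less inhibition. Compound 1 `Clc1ccc(N2CCN(CCCOc3ccc4c(c3)CCC4)CC2)cc1` gives 58%, while compound 2 `COc1ccc(N2CCN(CCCOc3ccc4c(c3)CCC4)CC2)cc1` gives 37%. Going by the values given here, compound 2 thus stands at the lower of the two numbers, and the only measured step, a number 21 percentage points lower from compound 1 to compound 2 (beyond the scatter), shows how far a change on an aromatic carbon can move the read-out. Compound 3 `O=[N+]([O-])c1ccccc1N1CCN(CCCOc2ccc3c(c2)CCC3)CC1` is not yet measured; it differs from compound 2 by 2-nitrophenyl in place of 4-methoxyphenyl on an amine nitrogen in a ring. Among the compounds with values here, no measured step covers this exchange directly; the single step that exists serves only as a guide to size, since a swap of one group for another on the same part of the molecule shifted this assay by a modest amount. The step from compound 2 to compound 3 is therefore expected to be modest and uncertain in direction, as a number 8 percentage points higher from compound 2 to compound 3 (within the scatter). Compound 3 is estimated to give 45%, with a range from 20% to 70%.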

Compound 3, a percentage reported as inhibition, in the whole organism at one dose (the size of the read-out at that dose, not a potency): 43%
For compound 3 the middle estimate is 2 percentage points above the measured one; measured number inside the range.
By their numbers in this assay, from the lowest: compounds 2 and 3 (each within the scatter of the next); then compound 1.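

In this assay, 2-nitrophenyl in place of 4-methoxyphenyl on the amine nitrogen in a ring gives a number 6 percentage points higher from compound 2 to compound 3 (within the scatter), so two quite different aryl groups at this position cannot be told apart in this read-out. Set against 4-chlorophenyl, the same group gives a number 15 percentage points lower from compound 1 to compound 3 (beyond the scatter), which makes compound 1 the only one of the three that stands clear of the others. No evidence at hand accounts for this difference.

The compounds shown leave open whether the nitro group or its place on the ring decides the result, which 4-nitrophenyl on the same nitrogen would separate. They also leave open whether the higher number of compound 1 belongs to chloro in particular, or would also appear with 4-fluorophenyl or unsubstituted phenyl.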